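Allyl in Place of Propyl on the Amine Chain

The source may report more compounds than this note shows. Statements on the series, on what has been measured and on what is new or still open speak of the compounds shown alone.

Compound 2 `CCCNc1nc(NCc2ccc(C(=O)Nc3ccc(F)cc3)cc2)c2ccccc2n1` is measured in a functional assay on SW480 cells (Homo sapiens) for inhibition, read by luminescence and resazurin assay, with a stated time of 3 days (a higher number here means a weaker inhibitor, a lower number a stronger inhibitor), where compound 2 gives 1600 nM. Compound 1 `CCCNc1nc(NCc2ccc(NC(=O)c3ccc(F)cc3)cc2)c2ccccc2n1` gives 2000 nM; the step from compound 1 to compound 2 is a 1.3-fold lower number from compound 1 to compound 2 (0.10 log units; within the scatter), and that change, an amide turned around, concerns a different part of the molecule. Compound 3 `CCCNc1nc(NCc2ccc(C(=O)NC3CCN(Cc4ccc(F)cc4)CC3)cc2)c2cc(C)ccc2n1`, with a different tail, gives 1100 nM. Compound 2 thus sits within the scatter of both neighbours. Compound 4 `C=CCNc1nc(NCc2ccc(C(=O)Nc3ccc(F)cc3)cc2)c2ccccc2n1` differs from compound 2 by vinyl in place of ethyl on a saturated chain carbon bound to a nitrogen on an aromatic ring. No measured pair alters this chain, so nothing shown bears on the change, and a step beyond the scatter is not expected in this assay. Compound 4 is therefore expected to give about 1600 nM, within 600 nM to 4000 nM. The expected step from compound 2 to compound 4 is no change at the digits printed from compound 2 to compound 4 (within the scatter).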

Compound 4, half-maximal inhibitory concentration: 11000 nM
Compound 4: the middle estimate sits 6.9-fold (0.84 log units) below what was measured, outside the stated range (above it).
By their numbers in this assay, from the lowest: compounds 3, 2 and 1 (each within the scatter of the next); then compound 4.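

Going by these compounds alone, the one earlier step, an amide turned around elsewhere in the molecule, stayed within the scatter, whereas propyl to allyl, which keeps the heavy-atom count and adds one double bond, gives a 6.9-fold higher number from compound 2 to compound 4 (0.84 log units; beyond the scatter) in this assay and makes compound 4 the weaker inhibitor. This single pair shows that the propylamino chain is sensitive to even a small change. Nothing available explains this loss.

From the compounds shown here alone, whether a longer butyl chain or a shorter ethyl chain would hold activity remains open. So does whether allyl has the same effect on the different tail of compound 3.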